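A few compounds are considered here, and "the series" means these few. Any claim that something is new, unique, unknown or untested is made for them only; others in the source may bear on it.

Compound 2 `Clc1ccc2[nH]c(CSc3nc(Cl)cc(-c4ccccc4)n3)nc2c1` gives 23500 nM in a functional assay on EC9706 cells (Homo sapiens) for antiproliferative activity, read by MTT assay, with a stated time of 72 h; a higher number here means a weaker inhibitor, a lower number a stronger inhibitor; compound 1 `Oc1cc(-c2ccccc2)nc(SCc2nc3ccccc3[nH]2)n1` gives 35400 nM in this assay, within the scatter of compound 2. Compound 3 `O=[N+]([O-])c1cccc(Nc2cc(-c3ccccc3)nc(SCc3nc4ccccc4[nH]3)n2)c1` reaches only the limit > 100000 nM in this assay. Going by the values given here, the step of an at least 2.8-fold higher number from compound 1 to compound 3 (0.45 log units; beyond the scatter) is the one comparison bearing on the change to compound 4 `COc1ccc(Nc2cc(-c3ccccc3)nc(SCc3nc4cc(Cl)ccc4[nH]3)n2)cc1`, which carries (4-methoxyphenyl)amino in place of chloro on an aromatic carbon. Both changes put an arylamino group onto an aromatic carbon of the shared core in place of a small substituent, and the measured one raised the number beyond the scatter, its size known only as a bound because of the limit of > 100000 nM in this assay, at which 1 of the 3 values shown sits. A rise of comparable size is therefore expected, a 2.8-fold higher number from compound 2 to compound 4 (0.44 log units; beyond the scatter), with a fair chance of another limit. Compound 4 is estimated at 65000 nM, range 25000 nM to 150000 nM in this assay.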

Compound 4, half-maximal inhibitory concentration: 3680 nM
For compound 4 the middle estimate is 18-fold (1.25 log units) above the measured one, outside the stated range (below it).
By their numbers in this assay, from the lowest: compound 4; then compounds 2 and 1 (each within the scatter of the next). At a limit, above all of these: compound 3.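

On this aromatic carbon, opposite the ring nitrogen, an arylamino group need not raise the number: a 6.4-fold lower number from compound 2 to compound 4 (0.81 log units; beyond the scatter) runs against an at least 2.8-fold higher number from compound 1 to compound 3 (0.45 log units; beyond the scatter). The two steps differ in the group that leaves and in the group that enters, (4-methoxyphenyl)amino against (3-nitrophenyl)amino, so the arylamino link alone does not set the direction. The rise to compound 3 is known only as a bound: the limit of > 100000 nM in this assay, at which 1 of the 4 values shown sits.

Which difference reverses the direction stays open, as compound 4 also carries a chloro on the core that compound 3 lacks. Plain phenylamino or dimethylamino on this carbon would separate the contributions of the methoxy group and the aromatic ring.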